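From 3-hydroxypropyl to 2-methoxyethyl on the shared core

This account rests on a few compounds, and the source may have more. Where it says the series, first, only, none or still open, it means among the compounds named here.

In a functional assay on HCT-116 cells (Homo sapiens) for antiproliferative activity (a lower number here means a stronger inhibitor, a higher number a weaker inhibitor), compound 1 `Cc1cc2c(F)c(Oc3ncnc(N)c3/C=N/O)ccc2[nH]1` gives 1140 nM with hydrogen on the oxygen, compound 2 `Cc1cc2c(F)c(Oc3ncnc(N)c3/C=N/OCc3ccccc3)ccc2[nH]1` gives 311 nM with benzyl there, and compound 3 `Cc1cc2c(F)c(Oc3ncnc(N)c3/C=N/OCCCO)ccc2[nH]1` gives 452 nM with 3-hydroxypropyl. Compound 3 therefore stands level with compound 2 within the scatter, and beyond the scatter under compound 1.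

Compound 4 `COCCO/N=C/c1c(N)ncnc1Oc1ccc2[nH]c(C)cc2c1F` has the same atoms as compound 3 joined differently, the change methoxy in place of hydroxymethyl on a saturated chain carbon, two bonds along the chain from an oxygen being methoxy in place of hydroxymethyl on a saturated chain carbon, two bonds along the chain from an oxygen. The 3-hydroxypropyl thus becomes 2-methoxyethyl.

Putting a chain on that oxygen gave the modest steps of a 3.7-fold lower number from compound 1 to compound 2 (0.56 log units; beyond the scatter) and a 2.5-fold lower number from compound 1 to compound 3 (0.40 log units; beyond the scatter) in this series. Compound 4 keeps such a chain, so its number is expected to stay near those of the chain-bearing members. Among the compounds with values here, no measured step covers this exact exchange. The nearest evidence is a 1.5-fold higher number from compound 2 to compound 3 (0.16 log units; within the scatter) for a far larger change in the chain, so the shift in this assay is expected to stay within the scatter, with no clear direction. The expected step is a 1.1-fold lower number from compound 3 to compound 4 (0.05 log units; within the scatter) and so none beyond the scatter. For compound 4 the estimate is 400 nM with an expected range from 190 nM to 850 nM for this measurement.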

Compound 4, half-maximal inhibitory concentration: 387 nM
Estimate against measurement, compound 4: 1.0-fold (0.01 log units) above, within the range that was stated.
By their numbers in this assay, from the lowest: compounds 2, 4 and 3 (each within the scatter of the next); then compound 1.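

Notes on the chain on the oxygen: in this assay there is a 1.2-fold lower number from compound 3 to compound 4 (0.07 log units; within the scatter) for methoxy in place of hydroxymethyl on a saturated chain carbon, two bonds along the chain from an oxygen, so at this place the hydrogen-bond donor of the hydroxymethyl can go, with the same count of heavy atoms, without a shift beyond the scatter. The aromatic ring of the benzyl is also not needed to reach this level: a 1.2-fold higher number from compound 2 to compound 4 (0.09 log units; within the scatter) keeps 2-methoxyethyl within the scatter of benzyl, whereas a 2.9-fold lower number from compound 1 to compound 4 (0.47 log units; beyond the scatter) makes 2-methoxyethyl the third chain separated beyond the scatter from the hydrogen of compound 1, and among compounds 2, 3 and 4 no chain stands apart beyond the scatter. No available measurement accounts for this similarity among the chains.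

Whether the same level holds with a basic or acidic end is open: a 2-aminoethyl or dimethylaminoethyl chain, or a carboxylic acid at the chain end, could answer that. A longer chain, such as 4-methoxybutyl, would show whether the tolerance seen with 3-hydroxypropyl, 2-methoxyethyl and benzyl extends further along the chain.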